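Working notes: exchanging the group on the chain carbon

The compounds below may be only part of what the source reports. "The series", "measured", "known", "first", "only" and "open" are said of these compounds alone.

Measured in a functional assay on HepG2 cells (Homo sapiens) for inhibition, read by MTT assay, with a stated time of 3 days; on this read-out lower numbers stand for stronger inhibition and higher numbers for weaker inhibition:
- compound 1 `COc1cc(-c2nc3ccccc3s2)ccc1OCC(=O)NNC(=O)CCl`: 2890 nM
- compound 2 `COc1cc(-c2nc3ccccc3s2)ccc1OCC(=O)NNC(=O)CN[C@@H](CCSC)C(=O)O`: 3780 nM
- compound 3 `CCOC(=O)[C@H](CS)N(CC(=O)NNC(=O)COc1ccc(-c2nc3ccccc3s2)cc1OC)C(C)=O`: 3010 nM

Compound 3 stands within the scatter of both other compounds, with a 1.0-fold higher number from compound 1 to compound 3 (0.02 log units; within the scatter) and a 1.3-fold lower number from compound 2 to compound 3 (0.10 log units; within the scatter). Compound 4 `CCOC(=O)[C@H](CCSC)NCC(=O)NNC(=O)COc1ccc(-c2nc3ccccc3s2)cc1OC` is still unmeasured. The change is (1-(ethoxycarbonyl)-3-(methylsulfanyl)propyl)amino in place of acetyl(1-(ethoxycarbonyl)-2-sulfanylethyl)amino on a saturated chain carbon bound to a carbonyl carbon, with (1-(ethoxycarbonyl)-3-(methylsulfanyl)propyl)amino in place of acetyl(1-(ethoxycarbonyl)-2-sulfanylethyl)amino. The remaining measured step, a 1.3-fold higher number from compound 1 to compound 2 (0.12 log units; within the scatter), also stayed within the scatter, so all three exchanges at this place were small. No step beyond the scatter is therefore expected in this assay. The expected step is a 1.1-fold higher number from compound 3 to compound 4 (0.03 log units; within the scatter). Compound 4 is estimated at 3200 nM, within a range of 1700 nM to 6000 nM.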

Compound 4, half-maximal inhibitory concentration: 3330 nM
For compound 4 the middle estimate is 1.0-fold (0.02 log units) below the measured one; the measured number falls inside the stated range.
By their numbers in this assay, from the lowest: compounds 1, 3, 4 and 2 (each within the scatter of the next).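

In this assay, a fourth group on a saturated chain carbon bound to a carbonyl carbon, (1-(ethoxycarbonyl)-3-(methylsulfanyl)propyl)amino, again stays within the scatter of the earlier groups (a 1.1-fold higher number from compound 3 to compound 4 (0.04 log units; within the scatter); a 1.2-fold higher number from compound 1 to compound 4 (0.06 log units; within the scatter)). The series also gains its first change away from that carbon, ethyl in place of hydrogen on an oxygen next to a carbonyl group, and this too stays within the scatter (a 1.1-fold lower number from compound 2 to compound 4 (0.06 log units; within the scatter)). No evidence bears on why these numbers stay so close.

On these data alone, whether a phenyl or piperidine ring on this chain carbon would give a step beyond the scatter remains open. So does the outcome of any change to the shared core.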